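Morpholine to hydroxyazetidine amide: expected inhibition

The source may report more compounds than this note shows. Statements on the series, on what has been measured and on what is new or still open speak of the compounds shown alone.

Measured so far:
compound 1 `N#CC1(NC(=O)[C@@H]2C[C@@H](S(=O)(=O)c3ccccc3)C[C@H]2C(=O)N2CCOCC2)CC1`; in a functional assay on A20 cells (Mus musculus) for inhibition, with stated times of 1 h, 16 h and 24 h (on this read-out higher numbers stand for weaker inhibition and lower numbers for stronger inhibition), compound 1 gives 12 nM
compound 2 `N#CC1(NC(=O)[C@@H]2C[C@@H](S(=O)(=O)c3ccccc3)C[C@H]2C(=O)N2CCC2)CC1`; in this assay compound 2 gives 44 nM

Compound 1 holds the lower of the two numbers shown; its nearest neighbour is compound 2, and the step of a 3.7-fold higher number from compound 1 to compound 2 (0.56 log units; beyond the scatter) lies beyond the scatter. Compound 3 `N#CC1(NC(=O)[C@@H]2C[C@@H](S(=O)(=O)c3ccccc3)C[C@H]2C(=O)N2CC(O)C2)CC1` awaits measurement in this assay. Its difference from compound 1 is 3-hydroxyazetidin-1-yl in place of morpholin-4-yl on a carbonyl carbon. Among the measured compounds shown here, the one measured step that bears on this change is the ring exchange without the hydroxy group, a 3.7-fold higher number from compound 1 to compound 2 (0.56 log units; beyond the scatter), a modest weakening. For the measured compounds named here, no measured pair shows what the hydroxy group on the azetidine adds, so the new variant is placed near that step, perhaps slightly less far from compound 1. The expected step for compound 3 is a 2.5-fold higher number from compound 1 to compound 3 (0.40 log units; beyond the scatter). For compound 3 in this assay the estimate is 30 nM, within a range from 12 nM to 75 nM.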

Compound 3, half-maximal inhibitory concentration: 572 nM
Beside the measured number, compound 3's estimate is 19-fold (1.28 log units) below it; measured number outside the range, above it.
By their numbers in this assay, from the lowest: compound 1; then compound 2; then compound 3.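

In this assay the hydroxy group, not the ring exchange, accounts for most of the loss at this position, with a 13-fold higher number from compound 2 to compound 3 (1.11 log units; beyond the scatter) against the modest 3.7-fold higher number from compound 1 to compound 2 (0.56 log units; beyond the scatter) for the azetidine without it. The combined change gives a 48-fold higher number from compound 1 to compound 3 (1.68 log units; beyond the scatter) and so shows that this amide on a carbonyl carbon does not accept every small ring equally, and that a single added hydroxy on the azetidine can outweigh the ring exchange itself. No evidence at hand accounts for this loss.

From the compounds shown here alone, it remains open whether the loss is specific to the hydroxy group or extends to other groups on the azetidine, such as methoxy or an amine. Going by these compounds, it also remains open whether a hydroxy group costs as much on a larger ring, as in a 4-hydroxypiperidin-1-yl amide.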